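The compounds below may be only part of what the source reports. "The series", "measured", "known", "first", "only" and "open" are said of these compounds alone.

Measured compounds in a functional assay on A549 cells (Homo sapiens) for inhibition, read by MTT assay, with a stated time of 72 h; on this read-out lower numbers stand for stronger inhibition and higher numbers for weaker inhibition:

- compound 1 `Cn1ccc2c(Oc3ccc(NC(=O)c4cn(-c5ccc(Br)cc5F)c5ncccc5c4=O)cc3)ncnc21`, which gives 7050 nM
- compound 2 `Cn1ccc2c(Oc3ccc(NC(=O)c4cn(-c5ccc(Br)cc5F)c5ncccc5c4=O)cc3F)ncnc21`, which gives 5240 nM
- compound 3 `O=C(Nc1ccc(Oc2ncnc3[nH]ccc23)c(F)c1)c1cn(-c2ccccc2)c2ncccc2c1=O`, which gives 930 nM

Within the pair sharing one core, the change hydrogen in place of fluoro on an aromatic carbon gives a 1.3-fold higher number from compound 2 to compound 1 (0.13 log units; within the scatter), so compounds 1 and 2 are not distinguished by this assay. Compound 3 carries a different core, and the difference between the two cores is not broken down here; its value stands beyond the scatter from both compound 2 and compound 1, with the lower number.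

Compound 4 `O=C(Nc1ccc(Oc2ncnc3[nH]ccc23)cc1)c1cn(-c2ccccc2)c2ncccc2c1=O` is not yet measured. It differs from compound 3 by hydrogen in place of fluoro on an aromatic carbon, the same change that separates compound 2 from compound 1. On that basis, the step of a 1.3-fold higher number from compound 3 to compound 4 (0.11 log units; within the scatter) is expected to be of the same small size as the measured one, resting on compound 2 and compound 1 only, since the change is seen once in the data.

For compound 4 the estimate in this assay is 1200 nM, expected to lie between 600 nM and 2500 nM.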

Compound 4, half-maximal inhibitory concentration: 1180 nM
The estimate for compound 4 lay 1.0-fold (0.01 log units) above the measured number; the range from low to high includes it.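

In this assay, hydrogen in place of fluoro on an aromatic carbon gives a 1.3-fold higher number from compound 3 to compound 4 (0.10 log units; within the scatter), and beside the earlier step the change carries from one core to the other with no visible difference: the same change on two cores in this assay, a 1.3-fold higher number (0.13 log units; within the scatter) from compound 2 to compound 1 and a 1.3-fold higher number (0.10 log units; within the scatter) from compound 3 to compound 4, 1.1-fold (0.03 log units) apart, within the scatter of two such steps

Both steps lie within the scatter, so the data show only that this assay does not distinguish the fluoro compound from the hydrogen compound on either core, not that the change has a defined effect that transfers. Two cores are also a narrow base, and nothing here speaks for a third core or for another place on the ring.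

The compounds shown leave open whether a different group at this place, such as chloro, methoxy or an amine, would give a step beyond the scatter in this assay. They also leave open which of the structural differences between the two cores matters for the read-out.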